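A few compounds are considered here, and "the series" means these few. Any claim that something is new, unique, unknown or untested is made for them only; others in the source may bear on it.

Measured so far in a functional assay on the whole organism for inhibition, with Chenopodium ficifolium as the target, with a stated time of 72 h, tested at 10 mg/L; a lower number here means less inhibition of growth, a higher number more inhibition of growth at the concentration tested:
compound 1 `COc1cc(SC)nc(NC(=S)NC(=O)c2c(-c3ccc(Cl)cc3Cl)noc2C)n1` gives -8.31%
compound 2 `COc1cc(Cl)nc(NC(=S)NC(=O)c2c(-c3ccc(Cl)cc3Cl)noc2C)n1` gives 21.9%
compound 3 `COc1cc(Cl)nc2n/c(=N/C(=O)c3c(-c4ccc(Cl)cc4Cl)noc3C)sn12` gives 19.3%

Compound 2 and compound 3 carry different cores; how the two cores differ is not broken down here, and their two values lie within the scatter of each other. On the core of compound 2 one change is measured: methylsulfanyl in place of chloro on an aromatic carbon. Within the data shown here, it gave a number 30.2 percentage points lower from compound 2 to compound 1 (beyond the scatter), the only instance of this change among the measured compounds. Compound 4 `COc1cc(SC)nc2n/c(=N/C(=O)c3c(-c4ccc(Cl)cc4Cl)noc3C)sn12` is not yet measured and repeats the same kind of change on the core of compound 3: methylsulfanyl in place of chloro on an aromatic carbon. The surroundings of the place are not identical: in compound 2 the carbon is meta to a large group, in compound 3 it is part of a fused or bridged system of two rings, meta to a fused ring and para to a fused ring. Among the measured compounds shown here, for compound 4 the step is expected to be a number 27.3 percentage points lower from compound 3 to compound 4 (beyond the scatter), resting on a number 30.2 percentage points lower from compound 2 to compound 1 (beyond the scatter) as the single earlier step of this kind and on compound 3 at 19.3% as the starting point. Compound 4 is thus estimated to give -8%, within a range from -25% to 10%.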

Compound 4, percent growth inhibition at one concentration: 23.8%
Estimate against measurement, compound 4: 31.8 percentage points below; the measured number lies above the stated range.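

In this assay methylsulfanyl in place of chloro gives a number 4.5 percentage points higher from compound 3 to compound 4 (within the scatter) and does not repeat the large drop seen on the other core. With one pair per core, this does not show which feature of the two cores goes with the gap, or how the change would behave on a further core. The step therefore cannot be carried from one core to the other in this series, as the two measured instances differ: the same change on two cores in this assay, a number 30.2 percentage points lower (beyond the scatter) from compound 2 to compound 1 and a number 4.5 percentage points higher (within the scatter) from compound 3 to compound 4, 34.7 percentage points apart, beyond the scatter of two such steps

Open, going by these compounds, is whether an amine or a longer thioether chain such as butylsulfanyl at this place would also separate the two cores. Also open, on these data alone, is whether the gap between the cores persists at concentrations other than the single one tested.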